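The compounds below may be only part of what the source reports. "The series", "measured", "known", "first", "only" and "open" are said of these compounds alone.

Three compounds measured in a functional assay on U-87MG ATCC cells for antiproliferative activity against U-87 MG (Homo sapiens), read by MTT assay, with a stated time of 48 h (on this read-out lower numbers stand for stronger inhibition and higher numbers for weaker inhibition), share a thioether-linked arrangement, though they fall into two groups by core. Compound 1 `COc1ccc(-c2nc(C)c(C(=O)CSc3nc(N)c(C#N)c(-c4ccc(Cl)cc4)n3)s2)cc1` gives 4540 nM in this assay, and compound 2 `COc1ccc(-c2nc(C)c(C(=O)CSc3nc(N)c(C#N)c(-c4ccccc4)n3)s2)cc1` gives 8540 nM. The change between them, (hydrogen in place of chloro on an aromatic carbon), produced a 1.9-fold higher number from compound 1 to compound 2 (0.27 log units; within the scatter). Compound 3 `Cc1nc(-c2ccccc2)sc1C(=O)CSc1nc(-c2cccc(Cl)c2)c(C#N)c(=O)[nH]1` carries a different core; the difference between the two cores is not broken down here. In this assay compound 3 gives 28200 nM, the highest number of the three.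

Compound 4 `Cc1nc(-c2ccccc2)sc1C(=O)CSc1nc(-c2ccccc2)c(C#N)c(=O)[nH]1` has not yet been measured. It differs from compound 3 by hydrogen in place of chloro on an aromatic carbon. Among the compounds with values here, this is the same kind of change as the one from compound 1 to compound 2, but the surroundings differ: in the first pair the place is para to a large group, in the new pair it is meta to a large group, and the cores are not the same. Resting on the earlier step of a 1.9-fold higher number from compound 1 to compound 2 (0.27 log units; within the scatter), compound 4 is expected to show a step of a 1.6-fold higher number from compound 3 to compound 4 (0.20 log units; within the scatter) from compound 3. The estimate for compound 4 in this assay is therefore 45000 nM, expected to lie between 20000 nM and 120000 nM.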

Compound 4, half-maximal inhibitory concentration: 56600 nM
Compound 4: middle estimate off by 1.3-fold (0.10 log units), on the low side; the range from low to high includes it.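

In this assay, replacing chloro with hydrogen on the aromatic ring, which turns 3-chlorophenyl into phenyl, gives a 2.0-fold higher number from compound 3 to compound 4 (0.30 log units; within the scatter). Set beside the same change on the core of compound 1, the step carries over to the core of compound 3 at much the same size: the same change on two cores in this assay, a 1.9-fold higher number (0.27 log units; within the scatter) from compound 1 to compound 2 and a 2.0-fold higher number (0.30 log units; within the scatter) from compound 3 to compound 4, 1.1-fold (0.03 log units) apart, within the scatter of two such steps. This does not show that the chloro group makes a real difference on either core, for each step on its own lies within the scatter, and two pairs with the chloro at different places on the ring are too few to support a general rule for the series.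

The compounds shown leave open whether another group at this place on the ring, such as an amine, a carboxylic acid or a longer chain, would shift the number beyond the scatter. Within the data shown here, they also leave open how much each difference between the two cores contributes on its own, as no pair here separates those differences.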